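Swapping a Sulfonyl for a Carbonyl on a Ring Nitrogen

This account rests on a few compounds, and the source may have more. Where it says the series, first, only, none or still open, it means among the compounds named here.

Of the compounds shown here, two sharing one core have been measured in an ADME assay on cells (Hepatocyte, Rattus norvegicus) for metabolic stability; on this read-out lower numbers stand for slow clearance and higher numbers for fast clearance. Compound 1 `Cc1ccc2[nH]c(C(=O)N[C@H]3CN(S(=O)(=O)c4cccnc4)C[C@@H]3C(=O)NCCN(C)C)cc2c1` gives 8 uL/min. Compound 2 `Cc1ccc2[nH]c(C(=O)N[C@H]3CCN(S(=O)(=O)c4cccnc4)C[C@@H]3C(=O)NCCN(C)C)cc2c1` gives 5 uL/min, the lowest of the two numbers, though the gap to compound 1 lies within the scatter, so the two cannot be ranked. Compound 3 `Cc1ccc2[nH]c(C(=O)N[C@H]3CCN(C(=O)c4cccnc4)C[C@@H]3C(=O)NCCN(C)C)cc2c1` is not yet measured; it differs from compound 2 in one place: (pyridin-3-yl)carbonyl in place of (pyridin-3-yl)sulfonyl on an amine nitrogen in a ring. Going by the values given here, no measured pair shows this change, so no direction can be read from the data; the expected step is a 1.2-fold higher number from compound 2 to compound 3 (0.08 log units; within the scatter), none beyond the scatter. Compound 3 is therefore estimated at 6 uL/min, with a range from 3 uL/min to 12 uL/min.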

Compound 3, intrinsic clearance in a liver preparation (reported as CLH), per the amount of preparation that the assay uses: 6 uL/min
The estimate for compound 3 equals the measured number at the digits printed; the measured number falls inside the stated range.
By their numbers in this assay, from the lowest: compounds 2, 3 and 1 (each within the scatter of the next).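

In this assay, placing (pyridin-3-yl)carbonyl in place of (pyridin-3-yl)sulfonyl on the amine nitrogen in the ring gives a 1.2-fold higher number from compound 2 to compound 3 (0.08 log units; within the scatter). Going by these compounds alone, this is the first direct view of the swap at this position, and it shows no difference that stands clear of the scatter. Still open, on these data alone, is how this assay would read with a smaller acetyl group on the same nitrogen, or with a phenyl group in place of the pyridin-3-yl part of the carbonyl group. No measured evidence bears on this result.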